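Adding an Amino Group to a Well-Tolerated Ester

The source may hold more compounds than are shown below. What is called first, only, known or untested is meant among the compounds shown, and "the series" means these compounds.

Two esters of the same bicyclic alcohol have been tested in an ADME assay on HEK-293T cells (Homo sapiens) for cytotoxicity, read by MTT assay, with a stated time of 48 h; a higher number here means that more compound is tolerated, a lower number that less compound is tolerated. Compound 1 `CC1CCN(CC(=O)O[C@@H]2C[C@@H]3CC[C@@]2(C)C3(C)C)CC1` is tolerated by the cells up to a half-maximal cytotoxic concentration of 71600 nM. Compound 2 `CCN1CCN(CC(=O)O[C@@H]2C[C@@H]3CC[C@@]2(C)C3(C)C)CC1` shows the higher of the two numbers, with 130000 nM, yet the gap to compound 1 stays within the usual scatter, so the two cannot be ranked against each other on these data.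

Compound 3 `CC1(C)[C@H]2CC[C@]1(C)[C@H](OC(=O)CN1CCN(CCN)CC1)C2` has not been measured yet. Compared with compound 2 it carries one change: amino in place of hydrogen on a saturated chain carbon, two bonds along the chain from an amine nitrogen in a ring. Among the compounds with values here, no measured pair illustrates this kind of change, so nothing on hand says how this assay responds to it. From compound 2 to compound 3 the step is expected to be no change at the digits printed from compound 2 to compound 3 (within the scatter), that is, no change beyond the scatter. Compound 3 is therefore expected to give about 130000 nM, within a range from 50000 nM to 320000 nM.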

Compound 3, half-maximal cytotoxic concentration: 247000 nM
Compound 3: the middle estimate sits 1.9-fold (0.28 log units) below what was measured, within the range that was stated.
By their numbers in this assay, from the lowest: compounds 1, 2 and 3 (each within the scatter of the next, the first and the last beyond it).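

In this assay, the measurement gives a 1.9-fold higher number from compound 2 to compound 3 (0.28 log units; within the scatter) when ethyl gives way to 2-aminoethyl. Within the data shown here, this is the first measured step at this position, and it shows that on this core the cells tolerate 2-aminoethyl and ethyl alike, as far as these data can separate them. Nothing measured here gives a reason for this result.

As far as these compounds go, it remains open how the assay would respond to a hydroxyl group or a carboxylic acid in place of the amino group, or to a longer chain ending in an amine. With a single step at this position, no trend along the chain can yet be drawn.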